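A few compounds are considered here, and "the series" means these few. Any claim that something is new, unique, unknown or untested is made for them only; others in the source may bear on it.

Measured so far in an ADME assay on MCF7 cells (Homo sapiens) for cytotoxicity, with a stated time of 72 h (on this read-out lower numbers stand for stronger inhibition and higher numbers for weaker inhibition), each entry a limit of the assay and not a number:
- compound 1 `Oc1ccc(CNc2ncnc3c2ncn3C2CCCCO2)cc1`: > 100000 nM
- compound 2 `COc1cc(CNc2ncnc3c2ncn3C2CCCCO2)ccc1O`: > 100000 nM
- compound 3 `COc1ccc(CNc2ncnc3c2ncn3C2CCCCO2)cc1OC`: > 100000 nM

Compound 2 stands at > 100000 nM, which is a limit. The same holds across the set: the limit of > 100000 nM in this assay, at which 3 of the 3 values shown sit.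

The next comparison is compound 4 `COc1cc(CNc2ncnc3c2ncn3C2CCCO2)ccc1O`, which carries oxolan-2-yl in place of oxan-2-yl on an aromatic nitrogen.

The measured steps are a step that the two limits leave unreadable from compound 1 to compound 2 and a step that the two limits leave unreadable from compound 2 to compound 3. Neither gives a size to carry over, and both lie elsewhere in the molecule, on an aromatic carbon and on an oxygen on an aromatic ring. Going by the values given here, no measured step covers this position.

No step beyond the scatter, in either direction, is expected in this assay from compound 2, because of the limit of > 100000 nM in this assay, at which 3 of the 3 values shown sit. The expected step is a number no higher from compound 2 to compound 4 (the limit leaves the size open). Compound 4 will most likely be reported as a limit again. For compound 4 the estimate is 100000 nM, with an expected range of 40000 nM to 200000 nM.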

Compound 4, half-maximal inhibitory concentration: > 100000 nM
Compound 4 was reported as a limit (the forecaster's own chance of this, stated with the estimate: 85%); the middle value sits exactly at the limit.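

No step can be read from compound 2 to compound 4: in this assay both entries are limits, not numbers, and the swap of oxan-2-yl for oxolan-2-yl gets no size. The compounds shown leave open whether any of these structures has a measurable value here.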